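Taking one acyl group off compound 2

This account rests on a few compounds, and the source may have more. Where it says the series, first, only, none or still open, it means among the compounds named here.

Values in (a functional assay on MCF7 cells (Homo sapiens) for inhibition, read by MTT assay, with a stated time of 72 h; a higher number here means a weaker inhibitor of growth, a lower number a stronger inhibitor of growth) so far:
Compound 1 (`CC(C)=CC(=O)NC(=N)N`) gives (> 100000 nM), a limit of the assay.
Compound 2 (`CC(C)=CCC/C(C)=C/C(=O)NC(=N)NC(=O)C=C(C)C`) gives (41500 nM).
Compound 3 (`CC(C)=CCC/C(C)=C/C(=O)NC(=N)N`) is not yet measured.

Among the measured compounds shown here, compound 2 holds the only actual number so far, and the other value is a limit. Compound 3 differs from compound 2 by one change (hydrogen in place of (2-methylprop-1-en-1-yl)carbonyl on an amine nitrogen): hydrogen in place of (2-methylprop-1-en-1-yl)carbonyl on an amine nitrogen. For the measured compounds named here, no measured pair shows what this change does. Compound 2 is already a weak inhibitor (41500 nM), so only a small shift towards weaker inhibition, not clearly beyond the scatter, is expected (a 1.4-fold higher number from compound 2 to compound 3 (0.16 log units; within the scatter)). For compound 3 the estimate is (60000 nM), with an expected range from (20000 nM) to (100000 nM).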

Compound 3, concentration for 50% growth inhibition: 52200 nM
Beside the measured number, compound 3's estimate is 1.1-fold (0.06 log units) above it; the measured number falls inside the stated range.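

In this assay, hydrogen in place of (2-methylprop-1-en-1-yl)carbonyl on the amine nitrogen gives a 1.3-fold higher number from compound 2 to compound 3 (0.10 log units; within the scatter), so this second acyl group makes no clear difference to growth inhibition. 3-Methylbut-2-en-1-yl in place of hydrogen on the chain gives an at least 1.9-fold lower number from compound 1 to compound 3 (0.28 log units; that floor lies within the scatter). That figure is only a floor, because compound 1 stands at a limit of the assay: the limit of > 100000 nM in this assay, at which 1 of the 3 values shown sits.

Going by these compounds, whether a longer chain would give a clearly stronger inhibitor remains open. So does the effect of a different group on that nitrogen, such as a benzoyl group.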